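Swapping a Fluorophenyl Amide for a Carboxyphenyl Amide

The compounds below may be only part of what the source reports. "The series", "measured", "known", "first", "only" and "open" are said of these compounds alone.

Two measured compounds share one core and differ only at an amide-type nitrogen. Compound 1 `COc1ccc(-n2nc(C(N)=O)nc2-c2cc(OC)c(OC)c(OC)c2)cc1` carries a plain amide; in a functional assay on the whole organism for inhibition, with Rattus norvegicus as the target, read by paw edema, with stated times of 30 min and 1 h, at a dose of 0.28 mmol/kg by the oral route (on this read-out higher numbers stand for more inhibition at the one dose given (going by the name of the read-out) and lower numbers for less inhibition), compound 1 gives 40%. Compound 2 `COc1ccc(-n2nc(C(=O)Nc3cccc(F)c3)nc2-c2cc(OC)c(OC)c(OC)c2)cc1` carries a 3-fluorophenyl on that nitrogen; in this assay compound 2 gives 48%. Compound 2 stands at the upper of the two values, but the step of a number 8 percentage points higher from compound 1 to compound 2 (within the scatter) lies within the scatter, so the two compounds cannot be separated on these numbers.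

Compound 3 `COc1ccc(-n2nc(C(=O)Nc3ccc(C(=O)O)cc3)nc2-c2cc(OC)c(OC)c(OC)c2)cc1` makes the next change: 4-carboxyphenyl in place of 3-fluorophenyl on an amide-type nitrogen. Among the measured compounds shown here, the only measured step, from compound 1 to compound 2, touched the same nitrogen and stayed within the scatter; no measured compound carries a carboxyl group, so its effect is unknown. On this basis the step of a number 3 percentage points lower from compound 2 to compound 3 (within the scatter) is expected to stay within the scatter. Compound 3 is therefore estimated at 45% in this assay, with a range from 25% to 65%.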

Compound 3, a percentage reported as inhibition, in the whole organism at one dose (the size of the read-out at that dose, not a potency): 50%
Compound 3: the middle estimate sits 5 percentage points below what was measured; the range from low to high includes it.
By their numbers in this assay, from the lowest: compounds 1, 2 and 3 (each within the scatter of the next).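

In this assay the exchange of 3-fluorophenyl for 4-carboxyphenyl on the amide-type nitrogen gives a number 2 percentage points higher from compound 2 to compound 3 (within the scatter) and so does not separate the two compounds. Compared with the plain amide, the 4-carboxyphenyl group gives a number 10 percentage points higher from compound 1 to compound 3 (within the scatter) as well, so hydrogen, 3-fluorophenyl and 4-carboxyphenyl on this nitrogen cannot be told apart on these numbers, even though the last of these adds a carboxyl group to the ring. No available measurement offers an explanation for this outcome.

The compounds shown leave open whether a different kind of group on this nitrogen, such as a 4-aminophenyl or a longer alkyl chain, would give a clearly different result. They also leave open whether these three compounds would separate at another dose, since each number comes from a single dose.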